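The source may report more compounds than this note shows. Statements on the series, on what has been measured and on what is new or still open speak of the compounds shown alone.

Within the data shown here, compound 2 `CCCC(=O)c1c(C)nn(CCCN2CCN(c3ccc(C)cc3)CC2)c(=O)c1N` gives 0% in a functional assay on the whole organism (Abdomen, strain Swiss) for inhibition, with Mus musculus as the target, with stated times of 30 min, 10 min and 5 min, at a dose of 10 mg/kg by the oral route (on this read-out higher numbers stand for a stronger effect at the one dose given and lower numbers for a weaker effect), and stands as the lower of the two numbers so far, a gap within the usual scatter from compound 1 `CCC(=O)c1c(C)nn(CCCN2CCN(c3ccc(C)cc3)CC2)c(=O)c1N`, which gives 9%; the step of a number 9 percentage points lower from compound 1 to compound 2 (within the scatter) shows no real difference. Compound 3 `C/C=C/c1c(C)nn(CCCN2CCN(c3ccc(C)cc3)CC2)c(=O)c1N` differs from compound 2 by prop-1-en-1-yl in place of propylcarbonyl on an aromatic carbon. Among the measured compounds shown here, the only measured step, methyl in place of hydrogen on a saturated chain carbon, touches the same propylcarbonyl but keeps the carbonyl, and bears on this change only weakly. With compound 1 at 9% and compound 2 at 0% both near zero, no step beyond the scatter is expected. Compound 3 is therefore estimated at 6%, range 0% to 25%, a step of a number 6 percentage points higher from compound 2 to compound 3 (within the scatter).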

Compound 3, a percentage reported as inhibition, in the whole organism at one dose (the size of the read-out at that dose, not a potency): 0%
Beside the measured number, compound 3's estimate is 6 percentage points above it; the measured number falls inside the stated range.
By their numbers in this assay, from the lowest: compounds 2, 3 and 1 (each within the scatter of the next).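

In this assay, removing the carbonyl from this aromatic carbon, opposite the ring nitrogen, gives no change at the digits printed from compound 2 to compound 3 (within the scatter) and a number 9 percentage points lower from compound 1 to compound 3 (within the scatter). The earlier step kept the carbonyl, whereas prop-1-en-1-yl has no hydrogen-bond acceptor, so the series now shows that this swap produces no difference beyond the scatter. No supporting data bear on this result.

With all three compounds near the bottom of the read-out, this position's contribution remains unresolved. Going by these compounds, whether an amine, a carboxylic acid or a longer chain on this carbon would give a clearly higher number stays open.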